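Halogen Swaps on the Phenyl Ring, Compound 3 to Compound 4

This account rests on a few compounds, and the source may have more. Where it says the series, first, only, none or still open, it means among the compounds named here.

Of the compounds shown here, three built on the same core have been measured in a functional assay on A549 cells (Homo sapiens) for cytotoxicity, read by MTT assay, with a stated time of 48 h; a lower number here means a stronger inhibitor, a higher number a weaker inhibitor. Compound 1 `COC(=O)c1c(-c2cc3ccccc3oc2=O)nn(-c2ccccc2)c1C(=O)OC` gives 28000 nM. Compound 2 `COC(=O)c1c(-c2cc3ccccc3oc2=O)nn(-c2cccc(Cl)c2)c1C(=O)OC`, which differs by chloro in place of hydrogen on an aromatic carbon, gives 30000 nM; that step, a 1.1-fold higher number from compound 1 to compound 2 (0.03 log units; within the scatter), lies within the scatter. Compound 3 `COC(=O)c1c(-c2cc3ccccc3oc2=O)nn(-c2cccc(F)c2)c1C(=O)OC` carries fluoro in place of hydrogen on that aromatic carbon and gives 50000 nM. Its position among the three is told by the two steps that lead to it, a 1.8-fold higher number from compound 1 to compound 3 (0.25 log units; within the scatter) and a 1.7-fold higher number from compound 2 to compound 3 (0.22 log units; within the scatter), both within the scatter, so the three numbers cannot be ranked.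

Compound 4 `COC(=O)c1c(-c2cc3ccccc3oc2=O)nn(-c2ccc(Br)cc2)c1C(=O)OC` has not yet been measured in this assay. Its difference from compound 3 is 4-bromophenyl in place of 3-fluorophenyl on an aromatic nitrogen. The measured steps that bear on this change are the three halogen swaps on the same ring, none of which moved the number beyond the scatter. Since every such exchange so far left the number where it was, as a 1.1-fold higher number from compound 1 to compound 2 (0.03 log units; within the scatter) and a 1.7-fold higher number from compound 2 to compound 3 (0.22 log units; within the scatter) show, the account expects no step beyond the scatter in this assay, with a 1.4-fold lower number from compound 3 to compound 4 (0.15 log units; within the scatter) as its estimate. Compound 4 is therefore estimated at 35000 nM, expected to fall between 15000 nM and 80000 nM.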

Compound 4, half-maximal inhibitory concentration: 165000 nM
Estimate against measurement, compound 4: 4.7-fold (0.67 log units) below, and the stated range ends below it.
By their numbers in this assay, from the lowest: compounds 1, 2 and 3 (each within the scatter of the next); then compound 4.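

In this assay, among these compounds, the group on the aromatic nitrogen turns out not to be indifferent to every exchange: 4-bromophenyl in place of 3-fluorophenyl gives a 3.3-fold higher number from compound 3 to compound 4 (0.52 log units; beyond the scatter), the first step in this set to pass the scatter. The separation holds against the other two groups as well, with 4-bromophenyl in place of 3-chlorophenyl giving a 5.5-fold higher number from compound 2 to compound 4 (0.74 log units; beyond the scatter) and 4-bromophenyl in place of phenyl giving a 5.9-fold higher number from compound 1 to compound 4 (0.77 log units; beyond the scatter), so the direction is the same from all three earlier compounds and each step is modest. Phenyl, 3-chlorophenyl and 3-fluorophenyl on this nitrogen remain unranked among themselves, and 4-bromophenyl alone stands apart from them, toward weaker inhibition.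

Nothing measured here speaks to why the number rises at this change. The halogen and its place on the ring change together between the 3-fluorophenyl and 4-bromophenyl groups, so the compounds shown leave open which of the two goes with the step, and also how this ring would answer to an amine or a carboxylic acid in place of the bromo group.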